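The compounds below may be only part of what the source reports. "The series", "measured", "known", "first", "only" and "open" are said of these compounds alone.

Measured compounds: compound 1 `CCCCCCNc1cc(-c2ccccc2)c(-c2ccccc2)nn1` gives 24000 nM; compound 2 `CCCCCCCCOc1cc(-c2ccccc2)c(-c2ccccc2)nn1` gives 104000 nM; compound 3 `CCCCCCCSc1cc(-c2ccccc2)c(-c2ccccc2)nn1` gives 76000 nM. All three were tested in an assay on microsomes from liver for inhibition of sterol O-acyltransferase 1 (Rattus norvegicus); on this read-out higher numbers stand for weaker inhibition and lower numbers for stronger inhibition.

Compound 3 stands second highest of the three numbers. Its nearest neighbour is compound 2, and that pair lies within the scatter, a 1.4-fold lower number from compound 2 to compound 3 (0.14 log units; within the scatter). Its furthest is compound 1, a 3.2-fold higher number from compound 1 to compound 3 (0.50 log units; beyond the scatter); the related move from compound 1 to compound 2 is a 4.3-fold higher number from compound 1 to compound 2 (0.64 log units; beyond the scatter). The three measured steps all concern the group joined to the shared core, not the far end of the chain.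

Compound 4 `O=C(O)CCCCCCCSc1cc(-c2ccccc2)c(-c2ccccc2)nn1` differs from compound 3 by carboxy in place of hydrogen on a saturated chain carbon, seven bonds along the chain from a sulfur. For the measured compounds named here, no measured step touches a carboxy group or the chain end, so nothing in these data bears on it directly. The expectation for compound 4 in this assay therefore rests on the absence of guidance: a change of roughly the measured scatter is estimated, with a wide margin, a 1.1-fold higher number from compound 3 to compound 4 (0.02 log units; within the scatter). The estimated value for compound 4 is 80000 nM, between 20000 nM and 300000 nM.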

Compound 4, half-maximal inhibitory concentration: > 300000 nM
Compound 4 ended at the assay's limit (the forecaster's own chance of this, stated with the estimate: 20%); middle value at least 3.7-fold (0.57 log units) away from the limit.
By their numbers in this assay, from the lowest: compound 1; then compounds 3 and 2 (each within the scatter of the next). At a limit, above all of these: compound 4.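

Compound 4 gives no number in this assay, only a limit: the limit of > 300000 nM in this assay, at which 1 of the 4 values shown sits. The earlier steps shown here all changed the group joining the chain to the shared core, whereas this one changes the far end of the chain, placing carboxy in place of hydrogen, seven bonds along the chain from a sulfur, and gives an at least 3.9-fold higher number from compound 3 to compound 4 (0.59 log units; beyond the scatter). So, for this one change, inhibition responds to what sits at the chain end and not only to what links the chain to the core, although the full size of the step stays unknown.

An amine, a hydroxy group or a methyl ester at the chain end could show whether this weakening is specific to the carboxylic acid. A shorter or longer chain carrying the same acid could show how much its distance from the sulfur matters.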